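From 3-hydroxypropyl to 3-cyanopropyl

The source may report more compounds than this note shows. Statements on the series, on what has been measured and on what is new or still open speak of the compounds shown alone.

In a functional assay on HT-29 cells (Homo sapiens) for inhibition, read by luminescence and CellTiter-Glo, with a stated time of 24 h (a higher number here means that more compound is needed for the effect, a lower number that less compound is needed), compound 1 `CN1C(=S)[C@@H](NC(=O)c2nc(Cc3ccccc3)n(C)n2)COc2ccccc21` gives 2.5 nM and compound 2 `CN1C(=S)[C@@H](NC(=O)c2nc(Cc3ccccc3)n(CCCO)n2)COc2ccccc21` gives 209 nM, the highest of the two numbers. Compound 3 `CN1C(=S)[C@@H](NC(=O)c2nc(Cc3ccccc3)n(CCCC#N)n2)COc2ccccc21` keeps the chain of compound 2 and changes its end: cyano in place of hydroxy on a saturated chain carbon, three bonds along the chain from an aromatic nitrogen, with cyano in place of hydroxy on a saturated chain carbon, three bonds along the chain from an aromatic nitrogen. Among the measured compounds shown here, no measured step isolates this change. The nearest evidence is an 84-fold higher number from compound 1 to compound 2 (1.92 log units; beyond the scatter), a large step beyond the scatter, and it brings in the chain and the hydroxy together, so it cannot separate the two. Part of that loss may be tied to the hydroxy, so only a partial return towards compound 1 is expected in this assay. The expected step is a 3.8-fold lower number from compound 2 to compound 3 (0.58 log units; beyond the scatter). For compound 3 the estimate is 55 nM, with an expected range of 12 nM to 250 nM.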

Compound 3, half-maximal effective concentration: 2400 nM
Estimate against measurement, compound 3: 44-fold (1.64 log units) below, outside the stated range (above it).
By their numbers in this assay, from the lowest: compound 1; then compound 2; then compound 3.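

In this assay the end of the chain counts on its own: with the chain kept, the change from hydroxy to cyano gives a further rise (an 11-fold higher number from compound 2 to compound 3 (1.06 log units; beyond the scatter)), so the loss seen on going to the hydroxy-ended chain is not the limit of what this position can lose. Against the unextended compound 1, the cyano-ended chain gives the largest step among these compounds (a 960-fold higher number from compound 1 to compound 3 (2.98 log units; beyond the scatter)), and of the two chain ends shown, hydroxy carries the lower number. Nothing at hand accounts for the gap between the 3-hydroxypropyl and 3-cyanopropyl ends.

Going by these compounds, how much of the rise belongs to the chain itself and how much to its end remains open. An amine or a carboxylic acid at the end of the propyl chain, or a shorter ethyl chain, would bear on that question.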